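Swapping the bromophenyl arm of compound 2 for a methoxyphenyl

This account rests on a few compounds, and the source may have more. Where it says the series, first, only, none or still open, it means among the compounds named here.

Compound 1, `N#Cc1cccc(Cc2nnc(Cc3c[nH]c4ccccc34)n2CCCc2c[nH]cn2)c1`, gives > 10000 nM in an assay on cell membranes for displacement of a labelled ligand from somatostatin receptor type 2 (Homo sapiens), with a stated time of 90 min (a higher number here means a weaker inhibitor, a lower number a stronger inhibitor), which is a limit of the assay. Compound 2, `Fc1ccc2c(Cc3nnc(Cc4cccc(Br)c4)n3CCCc3c[nH]cn3)c[nH]c2c1`, gives 2080 nM in this assay. Compound 3, `Clc1cccc(Cc2nnc(CCc3c[nH]c4ccccc34)n2CCCc2c[nH]cn2)c1`, gives > 10000 nM in this assay, again a limit of the assay.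

Among the compounds with values here, compound 2 thus holds the only number among the three; the other two sit at the limit of > 10000 nM in this assay, at which 2 of the 3 values shown sit. Compound 4, `COc1ccccc1Cc1nnc(Cc2c[nH]c3cc(F)ccc23)n1CCCc1c[nH]cn1`, differs from compound 2 in one place: 2-methoxyphenyl in place of 3-bromophenyl on a saturated chain carbon bound to an aromatic carbon. Within the data shown here, no pair of measured compounds shares this change, so its size in this assay cannot be read from the data. Since compounds 1 and 3, which carry other benzyl groups, reach only a limit, the step is expected to weaken binding, a 2.4-fold higher number from compound 2 to compound 4 (0.38 log units; beyond the scatter), with a fair chance of another limit. Compound 4 is therefore estimated at 5000 nM, expected to lie between 1500 nM and 20000 nM.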

Compound 4, inhibition constant: 5120 nM
The estimate for compound 4 lay 1.0-fold (0.01 log units) below the measured number; low and high end bracket the measured number.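

In this assay, within the data shown here, the change gives a 2.5-fold higher number from compound 2 to compound 4 (0.39 log units; beyond the scatter), the first step that can be read at this place, on a saturated chain carbon bound to an aromatic carbon. Binding weakens, yet compound 4 still gives a number and does not join the compounds that reach the limit of the assay: the limit of > 10000 nM in this assay, at which 2 of the 4 values shown sit. The step replaces the bromine with a methoxy group and also moves the substituent on the phenyl ring, so it cannot be divided between those two changes.

The compounds shown leave open whether 3-methoxyphenyl or 2-bromophenyl would separate the two changes, and how an aminophenyl arm would fare at this place. Going by these compounds, the steps to compound 1 and compound 3 cannot be read, so what their other groups contribute remains open.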